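Replacing the oxazole methylene group in the piperazine series

This account rests on a few compounds, and the source may have more. Where it says the series, first, only, none or still open, it means among the compounds named here.

Measured compounds:
- compound 1, `CCc1nc(C)c(CN2CCN(c3cccc4[nH]c(-c5ccc(C(C)(C)C)cc5)nc34)CC2)o1`, 37 nM
- compound 2, `CCc1cc(CN2CCN(c3cccc4[nH]c(-c5ccc(C(C)(C)C)cc5)nc34)CC2)nn1C`, 43 nM
- compound 3, `CCc1nc(CN2CCN(c3cccc4[nH]c(-c5ccc(C(C)(C)C)cc5)nc34)CC2)cn1C`, 18 nM

All three share one core and differ only in the five-membered aromatic ring carried on the saturated chain carbon bound to an amine nitrogen in a ring. In an assay on isolated protein for displacement of a labelled ligand from Gonadotropin-releasing hormone receptor (Homo sapiens) (on this read-out higher numbers stand for weaker inhibition and lower numbers for stronger inhibition), compound 1 stands second highest of the three numbers; its nearest neighbour is compound 2, with a 1.2-fold higher number from compound 1 to compound 2 (0.07 log units; within the scatter), and its furthest is compound 3, with a 2.1-fold lower number from compound 1 to compound 3 (0.31 log units; beyond the scatter). The remaining pair shows a 2.4-fold lower number from compound 2 to compound 3 (0.38 log units; beyond the scatter).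

Compound 4, `CCCCc1nc(CN2CCN(c3cccc4[nH]c(-c5ccc(C(C)(C)C)cc5)nc34)CC2)cn1C`, has not been measured. It differs from compound 1 in one place: 2-butyl-1-methyl-1H-imidazol-4-yl in place of 2-ethyl-4-methyl-1,3-oxazol-5-yl on a saturated chain carbon bound to an amine nitrogen in a ring.

The step from compound 1 to compound 3 bears directly on this, since both changes exchange the oxazole for a 1-methyl-1H-imidazol-4-yl ring; that step was a modest lowering of the number. Within the data shown here, no measured pair speaks to lengthening the chain on the imidazole from ethyl to butyl, so that part of the change carries no evidence here. The expectation for compound 4 in this assay is therefore a modest lowering relative to compound 1, close to what compound 3 showed, as a 1.9-fold lower number from compound 1 to compound 4 (0.27 log units; within the scatter). Compound 4 is estimated at 20 nM, within 8 nM to 50 nM.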

Compound 4, half-maximal inhibitory concentration: 26 nM
Estimate against measurement, compound 4: 1.3-fold (0.11 log units) below, within the range that was stated.
By their numbers in this assay, from the lowest: compounds 3, 4, 1 and 2 (each within the scatter of the next, the first and the last beyond it).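

In this assay the ethyl added to the chain on the imidazole, which turns the ethyl group of compound 3 into the butyl group of compound 4, gives a 1.4-fold higher number from compound 3 to compound 4 (0.16 log units; within the scatter) and shows that this position accepts the longer chain with no change that can be told from the scatter. The butyl imidazole also gives a 1.4-fold lower number from compound 1 to compound 4 (0.15 log units; within the scatter) against the oxazole and a 1.7-fold lower number from compound 2 to compound 4 (0.22 log units; within the scatter) against the pyrazole. The ethyl imidazole of compound 3 lies beyond the scatter of both those rings while the butyl imidazole of compound 4 does not, so the separation of the imidazole from the other two rings holds only for the ethyl member of this small set, and the two imidazoles themselves cannot be told apart.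

How far the chain on the imidazole can go remains open, since the compounds shown stop at butyl and say nothing of a hexyl chain, a branched isopropyl group, or a chain ending in an amine or a carboxylic acid. Nothing available gives a reason for any of these steps.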